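Benzyl in Place of Fluorophenyl on the Urea of Compound 2

This account rests on a few compounds, and the source may have more. Where it says the series, first, only, none or still open, it means among the compounds named here.

Measured so far in a functional assay on cells (Neutrophil, Homo sapiens) for inhibition, with a stated time of 10 min; a higher number here means a weaker inhibitor, a lower number a stronger inhibitor:
compound 1 `CCOC(=O)c1cnn(CC(C)O)c1NC(=O)Nc1ccc(F)cc1`: 0.2 nM
compound 2 `CCOC(=O)c1cnn(CC(O)CC)c1NC(=O)Nc1ccc(F)cc1`: 1.9 nM
compound 3 `CCOC(=O)c1cnn(CC(C)O)c1NC(=O)Nc1ccccc1F`: 0.00055 nM

Compound 2 stands highest of the three numbers in this assay. Its nearest neighbour is compound 1, the step being a 9.5-fold higher number from compound 1 to compound 2 (0.98 log units; beyond the scatter), which comes from methyl in place of hydrogen on a saturated chain carbon, two bonds along the chain from an oxygen on a saturated carbon. Compound 3 lies furthest away, and its value of 0.00055 nM is far below that of compound 2.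

Compound 4 `CCOC(=O)c1cnn(CC(O)CC)c1NC(=O)NCc1ccccc1` differs from compound 2 by benzyl in place of 4-fluorophenyl on an amide-type nitrogen. The step from compound 1 to compound 2 touches the chain and does not bear on this change. The step of a 360-fold lower number from compound 1 to compound 3 (2.56 log units; beyond the scatter) does bear on it, since it alters the same ring on the same amide-type nitrogen and shows that this position answers strongly to change. Within the data shown here, no measured step, however, exchanges the fluorophenyl for benzyl, so the direction rests on the weaker general footing that this assay is sensitive there. A step of a 16-fold higher number from compound 2 to compound 4 (1.20 log units; beyond the scatter) toward a higher number is therefore expected for compound 4, with wide uncertainty. Compound 4 is thus estimated at 30 nM, expected between 3 nM and 300 nM.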

Compound 4, half-maximal inhibitory concentration: 0.0074 nM
The estimate for compound 4 lay 4100-fold (3.61 log units) above the measured number, outside the stated range (below it).
By their numbers in this assay, from the lowest: compound 3; then compound 4; then compound 1; then compound 2.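

In this assay, the position on the amide-type nitrogen tolerates more than a change in where the fluorine sits on the ring: a 260-fold lower number from compound 2 to compound 4 (2.41 log units; beyond the scatter) shows that the ring need not be attached directly to that nitrogen, and that a benzyl group with no fluorine gives a far lower number than 4-fluorophenyl. Together with a 360-fold lower number from compound 1 to compound 3 (2.56 log units; beyond the scatter), this gives two large steps toward a lower number on leaving 4-fluorophenyl, although each was read with a different chain on the shared core. Nothing measured here explains why the number falls in either step.

The new step combines the loss of the fluorine with the attachment of the ring through a carbon, so the compounds shown leave open which of the two matters, a question that an unsubstituted phenyl or a fluorine-bearing benzyl on the same nitrogen would address. Also open, as far as these compounds go, are whether a longer chain such as phenylethyl continues the trend and whether benzyl gives a similar step when paired with the chain of compound 1.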